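Nitro in place of methyl: working notes

A few compounds are considered here, and "the series" means these few. Any claim that something is new, unique, unknown or untested is made for them only; others in the source may bear on it.

Measured so far:
compound 1 `O=C(CCCCCCC(=O)Nc1nc2ccccc2s1)NO` gives 6.61 ug/mL
compound 2 `CS(=O)(=O)c1ccc2nc(NC(=O)CCCCCCC(=O)NO)sc2c1` gives 15.4 ug/mL
compound 3 `Cc1ccc2nc(NC(=O)CCCCCCC(=O)NO)sc2c1` gives 1.6 ug/mL

In a functional assay on MCF7 cells (Homo sapiens) for cytotoxicity (on this read-out lower numbers stand for stronger inhibition and higher numbers for weaker inhibition), compound 3 has the lowest number of the three, and both of its gaps lie beyond the scatter (a 4.1-fold lower number from compound 1 to compound 3 (0.62 log units; beyond the scatter) and a 9.6-fold lower number from compound 2 to compound 3 (0.98 log units; beyond the scatter)). The next compound to be read is compound 4 `O=C(CCCCCCC(=O)Nc1nc2ccc([N+](=O)[O-])cc2s1)NO`, which carries nitro in place of methyl on an aromatic carbon.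

Among the measured compounds shown here, no measured step involves nitro, so the evidence is indirect. Methyl in place of hydrogen lowered the number (a 4.1-fold lower number from compound 1 to compound 3 (0.62 log units; beyond the scatter)), whereas methylsulfonyl in place of hydrogen raised it (a 2.3-fold higher number from compound 1 to compound 2 (0.37 log units; beyond the scatter)). Nitro resembles methylsulfonyl in carrying oxygen, which methyl does not, so compound 2 (15.4 ug/mL) is taken as the closer guide, though a loose one. A higher number than for compound 3 is therefore expected, probably by less than the full gap between the methylsulfonyl and methyl compounds. The expected step is modest but beyond the scatter (a 4.4-fold higher number from compound 3 to compound 4 (0.64 log units; beyond the scatter)). In this assay the estimate for compound 4 is 7 ug/mL (expected range 2.5 ug/mL to 20 ug/mL).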

Compound 4, half-maximal inhibitory concentration: 3.83 ug/mL
Beside the measured number, compound 4's estimate is 1.8-fold (0.26 log units) above it; low and high end bracket the measured number.
By their numbers in this assay, from the lowest: compound 3; then compounds 4 and 1 (each within the scatter of the next); then compound 2.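

In this assay, nitro on this aromatic carbon does not match methyl (a 2.4-fold higher number from compound 3 to compound 4 (0.38 log units; beyond the scatter)), but it does not match methylsulfonyl either (a 4.0-fold lower number from compound 2 to compound 4 (0.60 log units; beyond the scatter)). The two oxygen-bearing groups therefore part by a step beyond the scatter, so the presence of oxygen in the group does not by itself set the number in this short series. Nitro in place of hydrogen gives the only small step here (a 1.7-fold lower number from compound 1 to compound 4 (0.24 log units; within the scatter)), so on this read-out nitro cannot be told apart from hydrogen, whereas methyl and methylsulfonyl each move the number beyond the scatter in opposite directions (a 4.1-fold lower number from compound 1 to compound 3 (0.62 log units; beyond the scatter) and a 2.3-fold higher number from compound 1 to compound 2 (0.37 log units; beyond the scatter)).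

Nothing at hand explains this order of the groups. On these data alone, whether an amine or a carboxylic acid on this aromatic carbon would fall with methyl, with nitro and hydrogen, or with methylsulfonyl stays open, as does whether the same order would hold with the groups on another aromatic carbon of the shared core or with a longer chain to the hydroxamic acid end.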